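Arylidene thiazolidinedione acids in MCF7 cytotoxicity

The source may report more compounds than this note shows. Statements on the series, on what has been measured and on what is new or still open speak of the compounds shown alone.

Measured compounds in a functional assay on MCF7 cells (Homo sapiens) for cytotoxicity, read by MTT assay, with a stated time of 24 h; on this read-out lower numbers stand for stronger inhibition and higher numbers for weaker inhibition:
compound 1 `O=C(O)c1ccc(CN2C(=O)S/C(=C\c3ccccc3)C2=O)cc1`, 100000 nM;
compound 2 `O=C(O)c1ccc(CN2C(=O)S/C(=C\c3ccccn3)C2=O)cc1`, 90000 nM;
compound 3 `Cc1ccc(/C=C2\SC(=O)N(Cc3ccc(C(=O)O)cc3)C2=O)cc1`, 100000 nM.

Compound 3 gives a number level with compound 1, and its step to compound 2 is within the scatter, as are the steps of a 1.1-fold lower number from compound 1 to compound 2 (0.05 log units; within the scatter) and no change at the digits printed from compound 1 to compound 3 (within the scatter). All three numbers sit at the same weak level in this assay.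

Compound 4 `O=C(O)c1ccc(CN2C(=O)S/C(=C\c3ccco3)C2=O)cc1` differs from compound 3 by furan-2-yl in place of 4-methylphenyl on a double-bonded chain carbon bound to a double-bonded ring carbon. Among the compounds with values here, the steps that bear on it are the aryl swaps a 1.1-fold lower number from compound 1 to compound 2 (0.05 log units; within the scatter) and a 1.1-fold higher number from compound 2 to compound 3 (0.05 log units; within the scatter), both within the scatter; no step among the measured compounds moved the number beyond it. Compound 4 is therefore expected to give 100000 nM, range 45000 nM to 200000 nM, a step of no change at the digits printed from compound 3 to compound 4 (within the scatter) that is expected to stay within the scatter.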

Compound 4, half-maximal inhibitory concentration: 90000 nM
The estimate for compound 4 lay 1.1-fold (0.05 log units) above the measured number; the measured number falls inside the stated range.
By their numbers in this assay, from the lowest: compounds 2, 4, 1 and 3 (each within the scatter of the next).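

In this assay the steps of a 1.1-fold lower number from compound 3 to compound 4 (0.05 log units; within the scatter) and no change at the digits printed from compound 2 to compound 4 (within the scatter) and a 1.1-fold lower number from compound 1 to compound 4 (0.05 log units; within the scatter) place furan-2-yl, with its five-membered aromatic ring and its hydrogen-bond acceptor, level with the six-membered aromatic groups on a double-bonded chain carbon bound to a double-bonded ring carbon. Among these four compounds, a change of ring size at this place gives no step beyond the scatter. No measured evidence bears on why the numbers stay level.

From the compounds shown here alone, whether an amine or a longer chain at this place would move the number away from this weak level stays open. The compounds shown give no step beyond the scatter to compare it with.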